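Swapping chloro for methyl on a weak compound

A few compounds are considered here, and "the series" means these few. Any claim that something is new, unique, unknown or untested is made for them only; others in the source may bear on it.

Compound 1 `COc1cc(-c2ccnc3cc(-c4ccc(F)cc4)nn23)cc(OC)c1OC` gives 4540 nM
Compound 2 `COc1cc(-c2ccnc3cc(-c4c[nH]c5ccccc45)nn23)cc(OC)c1OC` gives 40 nM
Compound 3 `COc1cc(-c2ccnc3cc(-c4ccc(Cl)cc4)nn23)cc(OC)c1OC` gives 4090 nM

These values come from a functional assay on B16-F0 cells (Mus musculus) for inhibition, read by CCK-8 assay, with a stated time of 48 h (a higher number here means a weaker inhibitor, a lower number a stronger inhibitor), where compound 3 sits level with compound 1 within the scatter, and far on the weak side of compound 2 with a 100-fold higher number from compound 2 to compound 3 (2.01 log units; beyond the scatter) as the gap. Compound 4 `COc1cc(-c2ccnc3cc(-c4ccc(C)cc4)nn23)cc(OC)c1OC` differs by one small swap (methyl in place of chloro on an aromatic carbon) that is methyl in place of chloro on an aromatic carbon, para to a large group. The closest guide is a 1.1-fold lower number from compound 1 to compound 3 (0.05 log units; within the scatter) for chloro in place of fluoro. The large 110-fold lower number from compound 1 to compound 2 (2.05 log units; beyond the scatter) came with a far bigger change, 1H-indol-3-yl in place of 4-fluorophenyl. No methyl has been measured yet, so this assay is expected to show no step beyond the scatter. The expected shift is a 1.0-fold lower number from compound 3 to compound 4 (0.01 log units; within the scatter) as an estimate only. The estimate for compound 4 is 4000 nM with an expected range of 1800 nM to 9000 nM overall.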

Compound 4, half-maximal inhibitory concentration: 21 nM
Estimate against measurement, compound 4: 190-fold (2.28 log units) above, and the stated range ends above it.
By their numbers in this assay, from the lowest: compounds 4 and 2 (each within the scatter of the next); then compounds 3 and 1 (each within the scatter of the next).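

In this assay this position is far from indifferent: a 190-fold lower number from compound 3 to compound 4 (2.29 log units; beyond the scatter) and a 220-fold lower number from compound 1 to compound 4 (2.33 log units; beyond the scatter) show methyl standing well apart from chloro and fluoro, which sit level with each other. With a 1.9-fold lower number from compound 2 to compound 4 (0.28 log units; within the scatter) as the step to 4-methylphenyl, the 1H-indol-3-yl group is not the only route to a low number here. Nothing measured here explains why one atom swap matters so much.

From the compounds shown here alone, whether an ethyl or methoxy group at the same place would keep the low number remains open. So does the outcome for an amine there.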